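Swapping an aminoalkoxy side chain for bromine

The compounds below may be only part of what the source reports. "The series", "measured", "known", "first", "only" and "open" are said of these compounds alone.

Measured compounds:
Compound 1, `COc1cc(OC)c2c(=O)cc(-c3ccc(OC4CCN(C)CC4)cc3)oc2c1`: no number reported
Compound 2, `COc1cc(OC)c2c(=O)cc(-c3ccc(OCCN)cc3)oc2c1`: 70%
Compound 3, `COc1cc(OC)c2c(=O)cc(-c3ccc(OCC(O)CN(C)C)cc3)oc2c1`: 71%

Three compounds share one core and differ only in the group on the outer six-membered ring of carbon only. In a functional assay (Homo sapiens) for antiproliferative activity, read by resazurin assay, with a stated time of 48 h, tested at 20 uM (a lower number here means a weaker effect, a higher number a stronger effect of the compound at the concentration tested), compound 1 gives "not determined" (no result reported), so it carries no number. In this assay compound 2 gives 70% and compound 3 gives 71%. Among the compounds with values here, the only single-point step between measured compounds is a number 1 percentage points higher from compound 2 to compound 3 (within the scatter). Compound 3 therefore holds the higher of the two numbers, yet its distance from compound 2 lies within the scatter, so neither can be called stronger.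

Compound 4, `COc1cc(OC)c2c(=O)cc(-c3ccc(Br)cc3)oc2c1`, has not yet been measured in this assay. It differs from compound 3 as follows: bromo in place of 3-(dimethylamino)-2-hydroxypropoxy on an aromatic carbon. Within the data shown here, no measured step covers the loss of the whole chain; the one known step only exchanged one chain for another and stayed within the scatter. The expectation for compound 4 is therefore uncertain, with a wide range on either side. On that basis compound 4 is estimated at 50%, between 15% and 85%, an expected change of a number 21 percentage points lower from compound 3 to compound 4 (beyond the scatter).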

Compound 4, a percentage reported as inhibition, at one concentration (the size of the read-out at that concentration, not a potency): 22%
Compound 4: the middle estimate sits 28 percentage points above what was measured; the range from low to high includes it.
By their numbers in this assay, from the lowest: compound 4; then compounds 2 and 3 (each within the scatter of the next).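

In this assay, exchanging one chain for another changed little, a number 1 percentage points higher from compound 2 to compound 3 (within the scatter), but losing the chain altogether is a different matter: the result is a number 49 percentage points lower from compound 3 to compound 4 (beyond the scatter), and the comparison with the shorter chain gives a number 48 percentage points lower from compound 2 to compound 4 (beyond the scatter). This aromatic carbon is therefore not indifferent to what it carries, since bromo, a single heavy atom with no hydrogen-bond donors or acceptors, goes with a far weaker read-out at the tested concentration than either of the two chains bearing nitrogen. No measurement at hand shows which feature of the departing chains accounts for this drop.

The compounds shown leave open whether the amine matters or simply the presence of a chain, a question that a 2-methoxyethoxy chain without nitrogen, compared with the 2-aminoethoxy chain of compound 2, or a single methoxy group in place of bromo, could begin to answer. They also leave open how a carboxylic acid at the end of the chain or a longer chain would fare, and the chain of compound 1 adds nothing here, as compound 1 gives "not determined" (no result reported).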